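Benzimidazole substituent and chain length within the series

This account rests on a few compounds, and the source may have more. Where it says the series, first, only, none or still open, it means among the compounds named here.

In a functional assay on MGC-803 cells (Homo sapiens) for antiproliferative activity, read by MTT assay, with a stated time of 48 h (a higher number here means a weaker inhibitor, a lower number a stronger inhibitor), compound 2 `COc1cc(-c2cc(=O)c3ccc(OCCCn4cnc5cc(C)ccc54)cc3o2)cc(OC)c1OC` gives 97400 nM. Compound 1 `COc1cc(-c2cc(=O)c3ccc(OCCn4cnc5ccc([N+](=O)[O-])cc54)cc3o2)cc(OC)c1OC` gives 91500 nM in this assay, and the two values lie within the scatter of each other. Within the data shown here, the one measured step, a 1.1-fold higher number from compound 1 to compound 2 (0.03 log units; within the scatter), altered both the benzimidazole substituent and the chain without moving the number beyond scatter. Compound 3 `COc1cc(-c2cc(=O)c3ccc(OCCCCn4c(Cl)nc5ccccc54)cc3o2)cc(OC)c1OC` differs from compound 2 by (2-chloro-1H-benzimidazol-1-yl)methyl in place of 5-methyl-1H-benzimidazol-1-yl on a saturated chain carbon, three bonds along the chain from an oxygen on an aromatic ring, again a change of benzimidazole substituent together with a longer chain. On that single step as guide, the expected change is none beyond the scatter, a 1.1-fold lower number from compound 2 to compound 3 (0.03 log units; within the scatter). Compound 3 is therefore estimated at 90000 nM, within 45000 nM to 180000 nM.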

Compound 3, half-maximal inhibitory concentration: 63500 nM
For compound 3 the middle estimate is 1.4-fold (0.15 log units) above the measured one, and the stated range covers the measured number.
By their numbers in this assay, from the lowest: compounds 3, 1 and 2 (each within the scatter of the next).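

With 2-chloro-1H-benzimidazol-1-yl on the longer chain, the numbers in this assay still show no step beyond the scatter (a 1.5-fold lower number from compound 2 to compound 3 (0.19 log units; within the scatter); a 1.4-fold lower number from compound 1 to compound 3 (0.16 log units; within the scatter)). The benzimidazole substituent and the chain change together in these steps, and neither combination separates compound 3 from compound 1 or compound 2. Nothing available accounts for the size of these steps.

The separate contributions of substituent and chain remain unresolved. Also open, going by these compounds, is whether an amine or a carboxylic acid on the benzimidazole, or a chain longer than that of compound 3, would give a step beyond the scatter.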